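Adding a Methoxy Group to a Sulfone Cytotoxicity Series

The source may hold more compounds than are shown below. What is called first, only, known or untested is meant among the compounds shown, and "the series" means these compounds.

The measured compounds:
compound 1, `COc1ccccc1/C=C/S(=O)(=O)Cc1ccc(OC)c([N+](=O)[O-])c1`, 20000 nM
compound 2, `COc1ccc(CS(=O)(=O)/C=C/c2ccccc2OC)cc1N`, 7500 nM
compound 3, `COc1ccc(/C=C/S(=O)(=O)Cc2ccc(OC)c([N+](=O)[O-])c2)cc1`, 25000 nM

In a functional assay on DU-145 cells (Homo sapiens) for cytotoxicity, read by trypan blue exclusion, with a stated time of 96 h (on this read-out lower numbers stand for stronger inhibition and higher numbers for weaker inhibition), compound 1 stands second highest of these three numbers, close to compound 3 and set apart from compound 2 by a 2.7-fold lower number from compound 1 to compound 2 (0.43 log units; beyond the scatter). Compound 4, `COc1ccc(CS(=O)(=O)/C=C/c2c(OC)cccc2OC)cc1[N+](=O)[O-]`, differs from compound 1 by methoxy in place of hydrogen on an aromatic carbon. Among the measured compounds shown here, the only step that speaks to a change on that ring is a 1.3-fold higher number from compound 1 to compound 3 (0.10 log units; within the scatter), a shift in where the methoxy sits that stayed within the scatter. The amino-for-nitro step concerns the other ring and does not bear here. For compound 4 the expected outcome is therefore no change at the digits printed from compound 1 to compound 4 (within the scatter), none beyond the scatter. Compound 4 is expected to give 20000 nM, within the range 8000 nM to 50000 nM.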

Compound 4, half-maximal inhibitory concentration: 20000 nM
Estimate against measurement, compound 4: no gap at the digits printed; the measured number falls inside the stated range.
By their numbers in this assay, from the lowest: compound 2; then compounds 1, 4 and 3 (each within the scatter of the next).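

In this assay, methoxy in place of hydrogen on an aromatic carbon, ortho to a large group and meta to a methoxy group, gave no change at the digits printed from compound 1 to compound 4 (within the scatter). The earlier compounds shown here showed only a methoxy moved on this ring, whereas this step shows that the ring can carry a second methoxy at this position with no shift beyond the scatter. Nothing available gives a reason for this outcome.

Going by these compounds, whether an amine or a carboxylic acid at this position would leave the number equally unmoved remains open. So does whether amino in place of nitro on the other ring would give a similar step with this added methoxy present.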